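A few compounds are considered here, and "the series" means these few. Any claim that something is new, unique, unknown or untested is made for them only; others in the source may bear on it.

Compound 1 `O=C(O)CCn1c(=O)oc2cc(OCc3ccccc3)c(Cl)cc21`: 1580 nM
Compound 2 `Cc1ccc([C@@H](C)Oc2cc3onc(CCC(=O)O)c3cc2Cl)nn1`: 3.16 nM
Compound 3 `C[C@@H](Oc1cc2onc(CCC(=O)O)c2cc1Cl)c1ccc(F)cn1`: 31.6 nM

All three values come from an assay on HEK293 cells for inhibition of kynurenine 3-monooxygenase (Homo sapiens), read by LC-MS, with a stated time of 20 h; on this read-out lower numbers stand for stronger inhibition and higher numbers for weaker inhibition. Among them, compound 1 stands at the highest number and is therefore the weakest inhibitor of the set; compound 3 comes nearest to it, and compound 2 lies furthest away. The step to compound 4 `CCOc1cc2oc(=O)n(CCC(=O)O)c2cc1Cl` is methyl in place of phenyl on a saturated chain carbon bound to an oxygen on an aromatic ring. Among the compounds with values here, only one measured step between compounds differing in a single place exists, a 10-fold higher number from compound 2 to compound 3 (1.00 log units; beyond the scatter). That step swaps one aromatic ring for another on a chain carbon of the same kind, but on a different core, and it shows that the group at that carbon can shift the number by a fair amount. Within the data shown here, no measured step removes an aromatic ring from that place altogether, so the direction for compound 4 rests on little evidence. Compound 1 already sits at the weak end, and the change takes away the ring. The expected outcome is a somewhat higher number, a 2.2-fold higher number from compound 1 to compound 4 (0.35 log units; beyond the scatter). Compound 4 is estimated at 3500 nM, with a range from 900 nM to 14000 nM.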

Compound 4, half-maximal inhibitory concentration: 398 nM
Compound 4: the middle estimate sits 8.8-fold (0.94 log units) above what was measured, outside the stated range (below it).
By their numbers in this assay, from the lowest: compound 2; then compound 3; then compound 4; then compound 1.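

Exchanging phenyl for methyl on a saturated chain carbon bound to an oxygen on an aromatic ring, which turns benzyloxy into ethoxy, gives a 4.0-fold lower number from compound 1 to compound 4 (0.60 log units; beyond the scatter) in this assay. On the core of compound 1, then, inhibition does not depend on an aromatic ring at this place, and the simple methyl does better than the phenyl. The earlier step, a 10-fold higher number from compound 2 to compound 3 (1.00 log units; beyond the scatter), only exchanged one aromatic ring for another on a different core, and no evidence is available to explain the gain seen here.

Still open, going by these compounds, is whether a longer chain, such as propyl, or an amine at the end of the chain would lower the number further. Also open, on these data alone, is whether the same exchange would have a similar effect on the core shared by compound 2 and compound 3.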